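Amide series at the receptor: branched amino side chain variants

A few compounds are considered here, and "the series" means these few. Any claim that something is new, unique, unknown or untested is made for them only; others in the source may bear on it.

Measured so far:
- compound 1, `CC[C@H](C)[C@H](N)CN(C(=O)[C@@H]1C[C@H]1c1ccccc1)c1ccc(-c2ccccc2)cc1`: 230 nM; 800 nM (2 entries)
- compound 2, `CC(C)C[C@H](N)CN(C(=O)C(C)Cc1ccccc1)c1ccc(-c2ccccc2)cc1`: 1.2 nM
- compound 3, `CC(C)C[C@@H](N)CN(C(=O)[C@@H]1C[C@H]1c1ccccc1)c1ccc(-c2ccccc2)cc1`: 1.8 nM

In a functional assay for agonist activity at G protein-coupled receptor 88 (Homo sapiens), read by HTRF and cAMP accumulation (a higher number here means that more compound is needed for the effect, a lower number that less compound is needed), compound 3 gives 1.8 nM. Among the compounds with a single number it holds the higher of the two, but the nearest entry, compound 2 at 1.2 nM, sits within the scatter of it, so no order between compound 2 and compound 3 can be read. Compound 1, which carries a branched chain with two stereocentres, stands apart: its repeat entries, (the several entries of compound 1 in this assay, 230 nM; 800 nM (2 entries)), spread beyond the scatter of each other and both lie well above the numbers of compound 2 and compound 3.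

Compound 4, `CC[C@@H](C)[C@H](N)CN(C(=O)[C@@H]1C[C@H]1c1ccccc1)c1ccc(-c2ccccc2)cc1`, has not yet been measured in this assay. It differs from compound 3 by 1-amino-2-methylbutyl in place of 1-amino-3-methylbutyl on a saturated chain carbon bound to an amide-type nitrogen. Compound 4 is a diastereomer of compound 1; without a measured step between them, only their two values can be compared once compound 4 is known.

Among the measured compounds shown here, no measured step covers this change. The expectation for compound 4 is a rise in this assay of about a 17-fold higher number from compound 3 to compound 4 (1.22 log units; beyond the scatter), taken as a middle course between the number of compound 3 and the values of compound 1. The estimate for compound 4 in this assay is 30 nM, with a range from 4 nM to 250 nM.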

Compound 4, half-maximal effective concentration: 1.4 nM
Beside the measured number, compound 4's estimate is 21-fold (1.33 log units) above it; measured number below the stated range.
By their numbers in this assay, from the lowest: compounds 2, 4 and 3 (each within the scatter of the next).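

In this assay, 1-amino-2-methylbutyl in place of 1-amino-3-methylbutyl on a saturated chain carbon bound to an amide-type nitrogen gives a 1.3-fold lower number from compound 3 to compound 4 (0.11 log units; within the scatter), so this position accepts either branched chain with no difference that can be read. The earlier numbers gave no sign of this, since compound 1 carries the same 1-amino-2-methylbutyl group and gives 230 nM; 800 nM (2 entries), whereas compound 4 gives 1.4 nM, and even the lower entry lies far above that number, so the spread of the repeats does not account for the gap: the several entries of compound 1 in this assay, 230 nM; 800 nM (2 entries). The gap therefore belongs to the configuration within the 1-amino-2-methylbutyl group, because nothing else separates the two: the fact that compounds 1 and 4 differ only in the configuration as drawn.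

Still open, as far as these compounds go, is whether a cyclopentyl ring or a longer chain such as 1-aminohexyl would be accepted at this position as well, and whether an N-methyl amine in place of the primary amine would keep these numbers. Also open, from the compounds shown here alone, is whether the same dependence on configuration appears with the acyl group of compound 2.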